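This account rests on a few compounds, and the source may have more. Where it says the series, first, only, none or still open, it means among the compounds named here.

Compound 1, with the structure `C=C(CC)C(=O)c1ccc(OCc2nc(-c3ccc(C(F)(F)F)cc3)cs2)c(C)c1C`, and compound 2, with the structure `C=C(C)C(=O)c1ccc(OCc2nc(-c3ccc(C(F)(F)F)cc3)cs2)c(C)c1C`, share one core and differ in a single spot: compound 2 carries hydrogen in place of methyl on a saturated chain carbon bound to a double-bonded chain carbon. In an assay on HL-60 cells for inhibition of glutathione S-transferase P (Homo sapiens), read by spectrophotometry, tested at 5 uM (on this read-out lower numbers stand for less inhibition and higher numbers for more inhibition at the one concentration tested (going by the name of the read-out)), compound 1 gives 0%, and in this assay compound 2 gives 3.6%. The step is a number 3.6 percentage points higher from compound 1 to compound 2 (within the scatter), so the two compounds cannot be told apart on this read-out.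

Compound 3, with the structure `C=C(CC)C(=O)c1ccc(OCc2nc(-c3ccc([N+](=O)[O-])cc3)cs2)cc1Cl`, is built on a different core; the difference between its core and the core of compound 1 is not broken down here. In this assay compound 3 gives 10.2%. Compared with compound 1, whose value is 0%, the number for compound 3 lies beyond the scatter, whereas compound 2, at 3.6%, lies within the scatter of compound 3.

Compound 4, with the structure `C=C(C)C(=O)c1ccc(OCc2nc(-c3ccc([N+](=O)[O-])cc3)cs2)cc1Cl`, has not yet been measured. It stands to compound 3 exactly as compound 2 stands to compound 1: it carries hydrogen in place of methyl on a saturated chain carbon bound to a double-bonded chain carbon. Since the same change was made once before, on a different core, and then gave the step of a number 3.6 percentage points higher from compound 1 to compound 2 (within the scatter), the expected step here is a number 1.8 percentage points higher from compound 3 to compound 4 (within the scatter), that is, a change too small to be told from the scatter. Accordingly compound 4 is expected to give about 12% in this assay, most likely between 2% and 22%, an expectation that rests on the one earlier pair only.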

Compound 4, a percentage reported as inhibition, at one concentration (the size of the read-out at that concentration, not a potency): 86.7%
Compound 4: the middle estimate sits 74.7 percentage points below what was measured; measured number above the stated range.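

In this assay, the change from ethyl to methyl on the core of compound 3 gives a number 76.5 percentage points higher from compound 3 to compound 4 (beyond the scatter), so the size of the effect seen on the core of compound 1 did not carry over to this second core: the same change on two cores in this assay, a number 3.6 percentage points higher (within the scatter) from compound 1 to compound 2 and a number 76.5 percentage points higher (beyond the scatter) from compound 3 to compound 4, 72.9 percentage points apart, beyond the scatter of two such steps

This shows that, in this series, the change cannot be treated as a fixed increment to be added to any core, since what it does on one core gave a poor guide to what it does on the other. It does not show why the two cores respond so differently. The difference between them is not broken down here, and two pairs of compounds are too few to set a rule for any further core.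

The compounds shown leave open which part of the core of compound 3 goes with the large step, and how a longer chain such as propyl would read in place of the ethyl or methyl on the same core. Each number is also a reading at a single concentration, so it says how much inhibition appeared there and leaves the potency of compound 4 open.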